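A new group on the carbonyl of compound 2

The source may hold more compounds than are shown below. What is called first, only, known or untested is meant among the compounds shown, and "the series" means these compounds.

Among the compounds with values here, compound 2 `CN(C(=O)c1cc(-c2ccccc2)n[nH]1)c1ccc(OCB2C=Cc3ccccc3N2)cc1` gives 5.67 mL/min/kg in an ADME assay (liver) for metabolic stability, with Liver microsome (Rattus norvegicus) as the target, using microsomes (a lower number here means slower removal, a higher number faster removal of the compound), and holds the only true number so far. In this assay compound 1 `CN(C(=O)c1csc(-c2cccnc2)n1)c1ccc(OCc2ccc3ccccc3n2)cc1` gives > 283 mL/min/kg as a limit of the assay and not as a number. Compound 3 `CN(C(=O)c1csc(-c2cccnc2)n1)c1ccc(OCB2C=Cc3ccccc3N2)cc1` keeps the rest of compound 2 but has 2-(pyridin-3-yl)-1,3-thiazol-4-yl, the group also carried by compound 1, in place of 3-phenyl-1H-pyrazol-5-yl on a carbonyl carbon (2-(pyridin-3-yl)-1,3-thiazol-4-yl in place of 3-phenyl-1H-pyrazol-5-yl on a carbonyl carbon). Within the data shown here, no measured pair shows this change alone. A rise beyond the scatter is expected, with an estimated step of a 7.1-fold higher number from compound 2 to compound 3 (0.85 log units; beyond the scatter) in this assay for this swap. The estimate for compound 3 is 40 mL/min/kg with an expected range (12 mL/min/kg to 150 mL/min/kg).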

Compound 3, clearance: > 283 mL/min/kg
Compound 3 ended at the assay's limit; the forecaster's own chance of this, stated with the estimate: 10%; at least 7.0-fold (0.84 log units) between middle value and limit.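

Putting 2-(pyridin-3-yl)-1,3-thiazol-4-yl in place of 3-phenyl-1H-pyrazol-5-yl on a carbonyl carbon gives an at least 49-fold higher number from compound 2 to compound 3 (1.69 log units; beyond the scatter) in this assay. The value of compound 3 is a limit of the assay and not a number, so the low number of compound 2 is lost with this one swap while the rest of the molecule stays the same. Compound 1 and compound 3 both sit at a limit, and the step between them cannot be read.

As far as these compounds go, both rings of the group change at once, so it stays open whether the thiazole or the pyridine carries the step. A 2-phenyl-1,3-thiazol-4-yl group on the carbonyl would separate the two.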